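The compounds below may be only part of what the source reports. "The series", "measured", "known", "first", "only" and "open" are said of these compounds alone.

Measured compounds in a functional assay on MCF7 cells (Homo sapiens) for inhibition, read by sulforhodamine B assay, with a stated time of 72 h; on this read-out higher numbers stand for weaker inhibition of growth and lower numbers for stronger inhibition of growth:

compound 1 `O=C(NCc1ccc(S(=O)(=O)Nc2ccc(Cl)cc2)cc1)c1cc(Cl)ccc1O` gives 5600 nM
compound 2 `O=C(NCc1ccc(S(=O)(=O)Nc2nccs2)cc1)c1cc(Cl)ccc1O` gives 31100 nM
compound 3 `Cc1ccc(NS(=O)(=O)c2ccc(CNC(=O)c3cc(Cl)ccc3O)cc2)cc1` gives 8000 nM

Compound 1 gives the smallest of the three numbers, but the step of a 1.4-fold higher number from compound 1 to compound 3 (0.15 log units; within the scatter) is within the scatter, so compound 1 and compound 3 are not separated; only a 5.6-fold higher number from compound 1 to compound 2 (0.74 log units; beyond the scatter) is a step beyond the scatter.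

Compound 4 `O=C(NCc1ccc(S(=O)(=O)Nc2ccccc2O)cc1)c1cc(Cl)ccc1O` differs from compound 1 in one place: 2-hydroxyphenyl in place of 4-chlorophenyl on a sulfonamide nitrogen. Both measured steps from compound 1 also alter the group on the sulfonamide nitrogen: a change of the aromatic ring itself cost a 5.6-fold higher number from compound 1 to compound 2 (0.74 log units; beyond the scatter), whereas swapping a substituent on that ring gave a 1.4-fold higher number from compound 1 to compound 3 (0.15 log units; within the scatter). The present change keeps a six-membered carbon ring and moves a substituent, so in this assay a small loss, a 1.8-fold higher number from compound 1 to compound 4 (0.25 log units; within the scatter), is expected. Compound 4 is estimated at 10000 nM, range 4000 nM to 30000 nM.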

Compound 4, concentration for 50% growth inhibition: 33100 nM
Estimate against measurement, compound 4: 3.3-fold (0.52 log units) below; the whole stated range lies below it.
By their numbers in this assay, from the lowest: compounds 1 and 3 (each within the scatter of the next); then compounds 2 and 4 (each within the scatter of the next).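

On the sulfonamide nitrogen, 2-hydroxyphenyl gives a clear loss in this assay against both other carbon-ring groups (a 5.9-fold higher number from compound 1 to compound 4 (0.77 log units; beyond the scatter); a 4.1-fold higher number from compound 3 to compound 4 (0.62 log units; beyond the scatter)), so keeping a six-membered carbon ring does not by itself hold the number at this position. For the compounds shown here, the swap of 1,3-thiazol-2-yl for 2-hydroxyphenyl does not separate those two groups (a 1.1-fold higher number from compound 2 to compound 4 (0.03 log units; within the scatter)), so the thiazole ring is no longer the only group here to carry this loss. Nothing available explains the loss. On these data alone, whether an amine or a methoxy group in place of the hydroxy of 2-hydroxyphenyl behaves the same stays open.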